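Acyl Chain Extension at an Ester in Compound 4

The source may report more compounds than this note shows. Statements on the series, on what has been measured and on what is new or still open speak of the compounds shown alone.

Compound 1 `CCc1oc([C@H](C)/C=C(\C)[C@H](OC(C)=O)[C@H](C)[C@@H](OC(=O)CC(C)C)[C@@H](C)c2oc([C@@H](C)[C@@H](O)CC)c(C)c(=O)c2C)c(C)c(=O)c1C`: in a functional assay on Hs 683 cells (Homo sapiens) for inhibition, read by MTT assay, with a stated time of 72 h (on this read-out lower numbers stand for stronger inhibition and higher numbers for weaker inhibition), compound 1 gives 30000 nM.
Compound 2 `CCC(=O)[C@@H](C)c1oc([C@H](C)[C@@H]2O[C@](O)([C@@H](C)c3oc(CC)c(C)c(=O)c3C)[C@@H](C)[C@@H](O)[C@@H]2C)c(C)c(=O)c1C`: in this assay compound 2 reaches only the limit > 100000 nM, which is a limit of the assay and not a number.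
Compound 3 `CCc1oc([C@H](C)/C=C(\C)[C@H](OC(C)=O)[C@H](C)[C@@H](OC(=O)CC(C)C)[C@@H](C)c2oc([C@@H](C)[C@H](CC)OC(C)=O)c(C)c(=O)c2C)c(C)c(=O)c1C`: in this assay compound 3 gives 24000 nM.

Compound 3 holds the lowest of the two numbers measured, but its nearest neighbour, compound 1, sits within the scatter of it, so the two cannot be told apart. Going by the values given here, the one measured step that touches compound 3 is the change from compound 1, a 1.3-fold lower number from compound 1 to compound 3 (0.10 log units; within the scatter), an acetyl in place of hydrogen on an oxygen on a saturated carbon, and it left the number essentially where it was.

Compound 4 `CCC(=O)O[C@@H](/C(C)=C/[C@@H](C)c1oc(CC)c(C)c(=O)c1C)[C@H](C)[C@@H](OC(=O)CC(C)C)[C@@H](C)c1oc([C@@H](C)[C@H](CC)OC(C)=O)c(C)c(=O)c1C` differs from compound 3 by methyl in place of hydrogen on a saturated chain carbon bound to a carbonyl carbon. Among the compounds with values here, the only comparable step in hand, from compound 1 to compound 3, altered the acyl substitution at an oxygen and produced no movement beyond the scatter. A further extension of the same kind, acetyl to propanoyl, is therefore expected to give no change beyond the scatter either, and the step from compound 3 to compound 4 is estimated as no change at the digits printed from compound 3 to compound 4 (within the scatter). For compound 4 in this assay the expected value is 24000 nM, with a range from 10000 nM to 60000 nM.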

Compound 4, half-maximal inhibitory concentration: 3000 nM
Compound 4: the middle estimate sits 8.0-fold (0.90 log units) above what was measured; the measured number lies below the stated range.
By their numbers in this assay, from the lowest: compound 4; then compounds 3 and 1 (each within the scatter of the next). At a limit, above all of these: compound 2.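

In this assay the acyl group at this oxygen proves to be a place where one added carbon registers: an 8.0-fold lower number from compound 3 to compound 4 (0.90 log units; beyond the scatter), the change being acetoxy to propanoyloxy, and this is the only step shown that lies beyond the scatter. Going by these compounds alone, the earlier step, a 1.3-fold lower number from compound 1 to compound 3 (0.10 log units; within the scatter), placed an acetyl on another oxygen and stayed within the scatter, so the two acylated oxygens do not respond alike in this one pair of steps, and a small change at one of them carries more weight than the earlier compounds suggested. No measurement shown gives a reason for this step.

The compounds shown leave open whether the trend goes on with a longer chain such as butanoyl or a branched one such as isobutyryl, or ends at propanoyl, since a single step fixes no trend. They also leave open whether the same acetyl to propanoyl change on the other acetylated oxygen of compound 3 would do the same, and what a free hydroxyl at this position would give.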